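Imidazole in Place of Pyrrole: No Gain Expected

This account rests on a few compounds, and the source may have more. Where it says the series, first, only, none or still open, it means among the compounds named here.

The study reads antiproliferative activity in a functional assay on KB cells (Homo sapiens) for antiproliferative activity, read by MTT assay, with a stated time of 48 h; a higher number here means a weaker inhibitor, a lower number a stronger inhibitor. Compound 1 `Cn1cc(C2=C(c3nn(CCn4ccnc4)c4ncccc34)C(=O)NC2=O)c2ccccc21` gives > 100000 nM in this assay, which is a limit of the assay and not a number. Compound 2 `Cn1cc(C2=C(c3nn(CCCn4cccc4)c4ncccc34)C(=O)N(c3ccccc3)C2=O)c2ccccc21` gives > 100000 nM in this assay, again a limit and not a number. Among the measured compounds shown here, compound 2 therefore stands at the limit of > 100000 nM in this assay, at which 2 of the 2 values shown sit, and no order between compound 2 and compound 1 can be drawn; both values show only that neither compound reached the measurable range.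

Compound 3 `Cn1cc(C2=C(c3nn(CCCn4ccnc4)c4ncccc34)C(=O)N(c3ccccc3)C2=O)c2ccccc21` has not yet been tested in this assay. It differs from compound 2 in one place: 1H-imidazol-1-yl in place of 1H-pyrrol-1-yl on a saturated chain carbon, three bonds along the chain from an aromatic nitrogen. For the measured compounds named here, no step between measured compounds is available to size this change. Compound 1 carries the entering group on a shorter chain and also sits at a limit, > 100000 nM, which gives no hint that the imidazole brings activity. The step expected from compound 2 to compound 3, a number no higher from compound 2 to compound 3 (the limit leaves the size open), is none beyond the scatter, and a limit is again the likely outcome. Compound 3 is estimated at 100000 nM, with a range from 40000 nM to 300000 nM.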

Compound 3, half-maximal inhibitory concentration: 6800 nM
For compound 3 the middle estimate is 15-fold (1.17 log units) above the measured one, outside the stated range (below it).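

In this assay, replacing 1H-pyrrol-1-yl with 1H-imidazol-1-yl on a saturated chain carbon, three bonds along the chain from an aromatic nitrogen, gives a clear result, with an at least 14-fold lower number from compound 2 to compound 3 (1.16 log units; beyond the scatter). This position therefore responds to the identity of the ring at the chain end, and compound 3 is the only one of the compounds shown to give a number rather than a limit: the limit of > 100000 nM in this assay, at which 2 of the 3 values shown sit. The entering ring carries 2 hydrogen-bond acceptors where the leaving ring carries 1, but nothing shown ties the gain to that count, and no measured property explains it.

From the compounds shown here alone, the full size of the step stays open, as the reading for compound 2 is a limit of the assay and not a number. Also open, going by these compounds, is whether a dimethylamino group or a 1H-1,2,4-triazol-1-yl ring at the end of the propyl chain, or a 4-(1H-imidazol-1-yl)butyl chain in place of the 3-(1H-imidazol-1-yl)propyl chain, would keep, raise or lose this activity.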